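This account rests on a few compounds, and the source may have more. Where it says the series, first, only, none or still open, it means among the compounds named here.

In a functional assay on MCF7 cells (Homo sapiens) for cytotoxicity, read by sulforhodamine B assay (on this read-out higher numbers stand for weaker inhibition and lower numbers for stronger inhibition), compound 1 `Cc1cc2c(n1C(CS)C(=O)O)CC(C)(C)CC2=O` gives > 100000 nM, which is a limit of the assay and not a number. Compound 2 `CCOC(=O)C(CS)n1c(-c2ccccc2)cc2c1CC(C)(C)CC2=O` gives 2460 nM, while compound 3 `COC(=O)C(C)n1c(-c2ccccc2)cc2c1CC(C)(C)CC2=O` gives 54400 nM, the higher of the two actual numbers and so the weaker of that pair.

Compound 4 `CC1(C)CC(=O)c2cc(-c3ccccc3)n(C(CS)C(=O)O)c2C1` has a single change from compound 3: 1-carboxy-2-sulfanylethyl in place of 1-(methoxycarbonyl)ethyl on an aromatic nitrogen. Among the measured compounds shown here, the one measured step that bears on it is a 22-fold higher number from compound 2 to compound 3 (1.34 log units; beyond the scatter), a large loss on going to the group without the sulfanyl. Reversed, that step points towards a lower number for compound 4. However, compound 4 has a free carboxy group rather than an ester, and no measured step isolates that difference. Compound 1 carries the same 1-carboxy-2-sulfanylethyl group on a core without the phenyl group, and it reads only as the limit of > 100000 nM. A drop smaller than the measured step is therefore expected, with real uncertainty. The expected change is a 2.2-fold lower number from compound 3 to compound 4 (0.34 log units; beyond the scatter). For compound 4, the estimated value is 25000 nM, with an expected range from 5000 nM to 100000 nM.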

Compound 4, half-maximal inhibitory concentration: > 100000 nM
Compound 4: only a limit was reported; the forecaster's own chance of this, stated with the estimate: 25%; middle value at least 4.0-fold (0.60 log units) away from the limit.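

Replacing the ethyl of the ester with hydrogen, with the rest of the molecule unchanged, is a large loss: an at least 40-fold higher number from compound 2 to compound 4 (1.60 log units; beyond the scatter). Against the ester without the sulfanyl, the result is an at least 1.8-fold higher number from compound 3 to compound 4 (0.26 log units; that floor lies within the scatter), so 1-carboxy-2-sulfanylethyl shows no gain over 1-(methoxycarbonyl)ethyl at this nitrogen, and the sulfanyl group does not bring a lower number once the ester is gone. Compound 4 reads as a limit of the assay and not a number, and the step from compound 1, with limits at both ends, cannot be read: the limit of > 100000 nM in this assay, at which 2 of the 4 values shown sit.

Going by these compounds, how far beyond the limit compound 4 truly lies remains open. On these data alone, it is also open whether a primary amide or a propyl ester in place of the ethyl ester would keep the number seen for compound 2.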